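A few compounds are considered here, and "the series" means these few. Any claim that something is new, unique, unknown or untested is made for them only; others in the source may bear on it.

Measured so far in an assay on membranes from brain for displacement of a labelled ligand from Sigma non-opioid intracellular receptor 1 (Cavia porcellus), read by scintillation counting, with a stated time of 120 min; on this read-out higher numbers stand for weaker inhibition and lower numbers for stronger inhibition:

Compound 1 `CCCCN1CCN(CCC(=O)Nc2nc3c(C)cccc3s2)CC1` gives 204 nM
Compound 2 `Cc1cccc2sc(NC(=O)CCN3CCN(C4CCCCC4)CC3)nc12` gives 24 nM
Compound 3 `Cc1cccc2sc(NC(=O)CCN3CCN(CCN(C(C)C)C(C)C)CC3)nc12` gives 809 nM

All three share one core and differ only in the group carried on the amine nitrogen of the six-membered ring that holds two nitrogens. Among these three numbers compound 1 stands second highest: compound 3 sits above it, with a 4.0-fold higher number from compound 1 to compound 3 (0.60 log units; beyond the scatter), and compound 2 sits well below it, with an 8.5-fold lower number from compound 1 to compound 2 (0.93 log units; beyond the scatter).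

Compound 4 `Cc1ccccc1N1CCN(CCC(=O)Nc2nc3c(C)cccc3s2)CC1` has not yet been measured. It differs from compound 1 in one place: 2-methylphenyl in place of butyl on an amine nitrogen in a ring.

Within the data shown here, the step that bears most directly on this change is the one from compound 1 to compound 2, which also swapped the butyl on that same ring nitrogen for a ring, and it gave a lower number, an 8.5-fold lower number from compound 1 to compound 2 (0.93 log units; beyond the scatter). The step from compound 2 to compound 3, a 34-fold higher number from compound 2 to compound 3 (1.53 log units; beyond the scatter), shows that the same nitrogen tolerates a chain far less well than a ring. A 2-methylphenyl is a ring, though an aromatic one rather than a saturated one, so a lower number than compound 1 is expected for compound 4, with the step estimated as a 2.3-fold lower number from compound 1 to compound 4 (0.36 log units; beyond the scatter). For compound 4 the estimate in this assay is 90 nM, within a range from 25 nM to 350 nM.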

Compound 4, inhibition constant: 1000 nM
For compound 4 the middle estimate is 11-fold (1.05 log units) below the measured one; measured number above the stated range.
By their numbers in this assay, from the lowest: compound 2; then compound 1; then compounds 3 and 4 (each within the scatter of the next).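

In this assay a ring on the amine nitrogen is not enough by itself: a 4.9-fold higher number from compound 1 to compound 4 (0.69 log units; beyond the scatter) runs the opposite way to the step from butyl to cyclohexyl, and the two rings end far apart, with a 42-fold higher number from compound 2 to compound 4 (1.62 log units; beyond the scatter) separating them. The earlier contrast between rings and chains therefore does not hold across these compounds, since the aromatic 2-methylphenyl of compound 4 and the 2-(diisopropylamino)ethyl chain of compound 3 cannot be told apart, with a 1.2-fold higher number from compound 3 to compound 4 (0.09 log units; within the scatter) as the whole of the gap between them. Of the four groups shown on this nitrogen, only the cyclohexyl of compound 2 gives a lower number than butyl, while compound 3 and compound 4 both go the other way, so the kind of group matters here and not simply the presence of a ring.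

No measurement at hand accounts for the wide gap between the two rings. As far as these compounds go, whether a plain phenyl without the methyl, or a benzyl, would sit nearer to compound 2 or to compound 4 stays open, so the aromatic ring and its methyl cannot yet be separated.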